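The source may hold more compounds than are shown below. What is called first, only, known or untested is meant among the compounds shown, and "the series" means these compounds.

Measured in a toxicity assay on mitochondria for inhibition; on this read-out higher numbers stand for weaker inhibition and lower numbers for stronger inhibition:
- compound 1 `CCc1cc(C(=O)n2cccc2)cc(C#N)c1O`: 6700 nM
- compound 2 `CCc1cc(C(=O)N2CC=CC2)cc(C#N)c1O`: > 100000 nM

The value of compound 2 is a limit of the assay and not a number. Compound 3 `CC(C)(C)c1cc(C(=O)N2CC=CC2)cc(C#N)c1O` has tert-butyl in place of ethyl on an aromatic carbon. Among the measured compounds shown here, the only measured step, an at least 14-fold higher number from compound 1 to compound 2 (1.17 log units; beyond the scatter), was large, but it lay on the carbonyl carbon, so it gives no size for a change at this other place. For the measured compounds named here, with no measured step at this place, only a small shift is expected, towards stronger inhibition if any can be seen: an at least 1.4-fold lower number from compound 2 to compound 3 (0.15 log units; that floor lies within the scatter). For compound 3 the estimated value is 70000 nM, with an expected range of 20000 nM to 200000 nM.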

Compound 3, half-maximal inhibitory concentration: 64000 nM
Beside the measured number, compound 3's estimate is 1.1-fold (0.04 log units) above it; low and high end bracket the measured number.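

Among the compounds shown here, compound 3 gives the first measured step at this position, on an aromatic carbon ortho to a hydroxy group: tert-butyl in place of ethyl brings an at least 1.5-fold lower number from compound 2 to compound 3 (0.19 log units; that floor lies within the scatter) in this assay. This shows no firm shift in inhibition, and the true size of the step stays unknown because compound 2 has a limit of the assay and not a number: the limit of > 100000 nM in this assay, at which 1 of the 3 values shown sits.

Still open, going by these compounds, is how a smaller group such as methyl, or an amine, would read at this position. Also open, on these data alone, is whether tert-butyl would move the number on the core of compound 1.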